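The source may hold more compounds than are shown below. What is called first, only, known or untested is meant among the compounds shown, and "the series" means these compounds.

Working notes on the series.

Compound 1 `CN(Cc1cccc(C(=O)O)c1)c1ccc(OCc2c(-c3c(Cl)cccc3Cl)noc2C2CC2)nc1C(F)(F)F` and compound 2 `CN(Cc1ccc(C(=O)O)cc1)c1ccc(OCc2c(-c3c(Cl)cccc3Cl)noc2C2CC2)nc1C(F)(F)F` share one core and differ only in the carboxylate position on the benzyl group. In a functional assay on HEK293 cells for agonist activity at Bile acid receptor (Homo sapiens), read by a luciferase reporter (a lower number here means a smaller maximal response, a higher number a larger maximal response), compound 1 gives 43%; compound 2 gives 60%. The step of a number 17 percentage points higher from compound 1 to compound 2 (beyond the scatter) is the only measured one here, and compound 2 stands highest of the two numbers, with compound 1 as its nearest neighbour.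

Compound 3 `CC(Nc1ccc(C(=O)O)cc1)c1ccc(OCc2c(-c3c(Cl)cccc3Cl)noc2C2CC2)nc1C(F)(F)F` has the same atoms as compound 2 joined differently: 1-((4-carboxyphenyl)amino)ethyl in place of (4-carboxybenzyl)(methyl)amino on an aromatic carbon. Among the compounds with values here, no measured step touches this change, since the one step in hand, a number 17 percentage points higher from compound 1 to compound 2 (beyond the scatter), moves only the carboxylate position and leaves the linker untouched. The rearrangement of the linker is therefore unanchored, and the expectation for this assay is a loss of uncertain size with wide bounds. Compound 3 is estimated at 48% in this assay, between 22% and 78%; this expected step is a number 12 percentage points lower from compound 2 to compound 3 (beyond the scatter).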

Compound 3, largest response reached (reported as efficacy), in percent of the reference or control that the assay uses: 49%
Compound 3: the middle estimate sits 1 percentage points below what was measured, and the stated range covers the measured number.
By their numbers in this assay, from the lowest: compounds 1 and 3 (each within the scatter of the next); then compound 2.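

In this assay, the linker itself matters as well as the carboxylate position: 1-((4-carboxyphenyl)amino)ethyl in place of (4-carboxybenzyl)(methyl)amino gives a number 11 percentage points lower from compound 2 to compound 3 (beyond the scatter) with the same heavy atoms, 2 hydrogen-bond donors in place of 1, and the same place on the aromatic ring. Set against (3-carboxybenzyl)(methyl)amino, the same group gives a number 6 percentage points higher from compound 1 to compound 3 (within the scatter) and so allows no ranking of these two compounds. No data in hand account for the change in maximal response on rearranging the linker.

The compounds shown leave open whether the branching methyl or the amine hydrogen carries the difference, which an unbranched aminomethyl linker would separate. Also open, as far as these compounds go, is whether a tetrazole could stand in place of the carboxylic acid on either linker.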